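Trimming the Nitrogen Substituent on a Glutamate Receptor Modulator

This account rests on a few compounds, and the source may have more. Where it says the series, first, only, none or still open, it means among the compounds named here.

Compound 1 `O=C(O)c1cc(-c2cccc(COc3ccc4c(c3)CN(Cc3ccc(C(F)(F)F)cc3)C4=O)c2)ccc1Cl` was tested in an assay on HEK293 cells for positive allosteric modulation of metabotropic glutamate receptor 2 (Rattus norvegicus), read by thallium flux (on this read-out lower numbers stand for smaller maximal responses and higher numbers for larger maximal responses), where compound 1 gives 86.7%. For the measured compounds named here, this is the only number available: compound 2 `CCCN1Cc2cc(OCc3cccc(-c4ccc(Cl)c(C(=O)O)c4)c3)ccc2C1=O` has "not determined" (no result reported) in this assay, so nothing can be compared with it. Compound 3 `O=C(O)c1cc(-c2cccc(COc3ccc4c(c3)CN(C3CC3)C4=O)c2)ccc1Cl` differs from compound 1 in one place: cyclopropyl in place of 4-(trifluoromethyl)benzyl on an amide-type nitrogen in a ring. Going by the values given here, no measured pair shows how such a change plays out here, so the expected step is a modest downward one, possibly no larger than the scatter. For compound 3 the estimated maximal response is 72%, between 45% and 98%, which means an expected step of a number 14.7 percentage points lower from compound 1 to compound 3 (beyond the scatter).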

Compound 3, largest response reached (Emax), in percent of the reference or control that the assay uses: 64.9%
For compound 3 the middle estimate is 7.1 percentage points above the measured one, and the stated range covers the measured number.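

In this assay the swap of 4-(trifluoromethyl)benzyl for cyclopropyl on the amide-type nitrogen gives a number 21.8 percentage points lower from compound 1 to compound 3 (beyond the scatter) and so shows that the group at this position affects the maximal response. Even so, compound 3 gives 64.9% with only 3 heavy atoms in the group on that nitrogen. Nothing available here explains the drop. The two groups differ in both size and ring type, and the fall cannot be assigned to either difference or to the trifluoromethyl group. On these data alone, an unsubstituted benzyl or a cyclohexyl on this nitrogen remains open.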